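The compounds below may be only part of what the source reports. "The series", "measured", "known", "first", "only" and "open" are said of these compounds alone.

Measured in a functional assay on CLL cells (Homo sapiens) for cytotoxicity, read by MTT assay, with a stated time of 48 h; a lower number here means that less compound is needed, a higher number that more compound is needed for the effect:
- compound 1 `C=C(CC)C(=O)c1ccc(OCC(=O)NCC(=O)O)c(Cl)c1Cl`: > 25000 nM (a limit of the assay, not a number)
- compound 2 `C=C(CC)C(=O)c1ccc(OCC(=O)Nc2nc3ccccc3s2)c(Cl)c1Cl`: 1500 nM
- compound 3 `C=C(CC)C(=O)c1ccc(OCC(=O)Nc2ccc(C(=O)O)c(O)c2)c(Cl)c1Cl`: > 25000 nM (a limit of the assay, not a number)

Compound 1 has no exact number in this assay, only a limit, and it shares that position with compound 3: the limit of > 25000 nM in this assay, at which 2 of the 3 values shown sit. Compound 4 `C=C(CC)C(=O)c1ccc(OCC(=O)Nc2cccc(C(=O)O)c2)c(Cl)c1Cl` has the same core as compound 1 but carries 3-carboxyphenyl in place of carboxymethyl on an amide-type nitrogen.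

For the measured compounds named here, only one measured step starts from compound 1. Putting 1,3-benzothiazol-2-yl on that nitrogen gave an at least 16-fold lower number from compound 1 to compound 2 (1.22 log units; beyond the scatter), a large step beyond the scatter. That might suggest that a ring here helps, but compound 4 also keeps a carboxyl group, which compound 2 lacks. Compound 3 is the closer guide, since it has both a ring on that nitrogen and a carboxyl group, and compound 3 gives > 25000 nM, which is a limit.

Going by the values given here, a large drop like the one to compound 2 is therefore not expected, and any step should be small at most, towards a lower number. The estimate means a number no higher from compound 1 to compound 4 (the limit leaves the size open), as expected from these few compounds. Compound 4 is expected at 25000 nM, with an estimated range of 10000 nM to 60000 nM.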

Compound 4, half-maximal effective concentration: 20600 nM
Estimate against measurement, compound 4: 1.2-fold (0.08 log units) above; measured number inside the range.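

In this assay, going by these compounds, putting a six-membered aromatic ring into the group on the amide-type nitrogen, as 3-carboxyphenyl in place of carboxymethyl, gives an at least 1.2-fold lower number from compound 1 to compound 4 (0.08 log units; that floor lies within the scatter), so this change shows no shift that can be told from the scatter, although the true size of the step stays open. The comparison with the other ring-bearing group is clearer, with a 14-fold higher number from compound 2 to compound 4 (1.14 log units; beyond the scatter), which shows that an aromatic ring on this nitrogen is not enough by itself to reach the level of compound 2. Compound 4 also gives an exact number for a group that keeps a carboxyl, whereas the comparison with compound 1 can only be read as a floor, and limits still make up much of this small set: the limit of > 25000 nM in this assay, at which 2 of the 4 values shown sit.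

The compounds shown do not separate the two differences between 3-carboxyphenyl and 1,3-benzothiazol-2-yl: the carboxylic acid and the kind of ring. An unsubstituted phenyl group on the same nitrogen, or a methyl ester in place of the carboxylic acid, would help tell these two differences apart.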